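The source may report more compounds than this note shows. Statements on the series, on what has been measured and on what is new or still open speak of the compounds shown alone.

Measured compounds:
compound 1 `CN(C)C(=O)c1cc2cnc(Nc3ccc(Cl)cc3)nc2n1C1CCCC1` — 13000 nM
compound 2 `CN(C)C(=O)c1cc2cnc(Nc3cccnc3)nc2n1C1CCCC1` — 26000 nM
compound 3 `O=C(c1cc2cnc(Nc3ccc(N4CCNCC4)cn3)nc2n1C1CCCC1)N1CCCCC1` — 39600 nM

In a functional assay on MIA PaCa-2 cells (Homo sapiens) for inhibition, read by MTT assay (a lower number here means a stronger inhibitor, a higher number a weaker inhibitor), compound 3 gives the highest number of the three. Against compound 2 its value sits within the scatter, while against compound 1 the gap is beyond it. Among the compounds with values here, the only step between compounds that differ in one place, a 2.0-fold higher number from compound 1 to compound 2 (0.30 log units; within the scatter), concerns the group on the nitrogen attached to the aromatic ring and lies within the scatter.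

Within the data shown here, compound 4 `O=C(Nc1ccccc1C(F)(F)F)c1cc2cnc(Nc3ccc(N4CCNCC4)cn3)nc2n1C1CCCC1` differs from compound 3 at a different position: (2-(trifluoromethyl)phenyl)amino in place of piperidin-1-yl on a carbonyl carbon No measured step touches the carbonyl carbon, so the one known step, a 2.0-fold higher number from compound 1 to compound 2 (0.30 log units; within the scatter), does not bear on this change, and the series gives no guide to its size or direction. Compound 1 and compound 2 both carry a dimethylamide, compound 3 a piperidin-1-yl amide, and none of them carries an amino group on the carbonyl carbon.

With nothing to rest on, compound 4 is expected to move no further than the scatter, a 1.6-fold lower number from compound 3 to compound 4 (0.20 log units; within the scatter), with a wide range allowed on either side. Compound 4 is therefore estimated at 25000 nM, between 6000 nM and 100000 nM.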

Compound 4, half-maximal inhibitory concentration: 3160 nM
Beside the measured number, compound 4's estimate is 7.9-fold (0.90 log units) above it; the measured number lies below the stated range.
By their numbers in this assay, from the lowest: compound 4; then compounds 1, 2 and 3 (each within the scatter of the next, the first and the last beyond it).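

In this assay, within the data shown here, the carbonyl carbon proves to be a position where the group matters: (2-(trifluoromethyl)phenyl)amino in place of piperidin-1-yl gives a 13-fold lower number from compound 3 to compound 4 (1.10 log units; beyond the scatter), a large step beyond the scatter, whereas the only earlier step, a 2.0-fold higher number from compound 1 to compound 2 (0.30 log units; within the scatter), lay within it and concerned a different position. Among these compounds, the change brings in an aromatic ring of carbon only and a hydrogen-bond donor together, and compound 4 is the only compound of the four with an amide hydrogen, so the series ties the step to the whole group and to no single part of it. No measurement at hand accounts for the size of this step.

The compounds shown leave open which part of the entering group goes with the step, the amide hydrogen, the aromatic ring or the trifluoromethyl group, a question on which a plain phenylamino or a cyclohexylamino group on the same carbonyl carbon would bear. They also leave open whether the step would carry over to compounds holding the 4-chlorophenyl or pyridin-3-yl groups of compound 1 and compound 2.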